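One Aryl Swap Carried Over to a Second Core

The source may report more compounds than this note shows. Statements on the series, on what has been measured and on what is new or still open speak of the compounds shown alone.

Measured so far, in a functional assay on the whole organism (strain Wistar) with Rattus norvegicus as the target, read by paw edema; on this read-out lower numbers stand for an effect already at smaller amounts and higher numbers for an effect only at larger amounts of compound:
Compound 1, `CCC(=O)OCc1cc(-n2nc(C(F)(F)F)cc2-c2ccc(Br)cc2)ccc1S(N)(=O)=O`, gives 17 mg/kg.
Compound 2, `CCC(=O)NS(=O)(=O)c1ccc(-n2nc(C(F)(F)F)cc2-c2ccc(Br)cc2)cc1CO`, gives 7.2 mg/kg.
Compound 3, `CCC(=O)OCc1cc(-n2nc(C(F)(F)F)cc2-c2ccc(OC)c(C)c2)ccc1S(N)(=O)=O`, gives 10.9 mg/kg.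

Compound 1 and compound 2 are built from the same atoms joined differently; the difference between these two cores is not broken down here. From compound 1 to compound 3 the change is 4-methoxy-3-methylphenyl in place of 4-bromophenyl on an aromatic carbon, and in this assay it gave a 1.6-fold lower number from compound 1 to compound 3 (0.19 log units; within the scatter). Compound 4, `CCC(=O)NS(=O)(=O)c1ccc(-n2nc(C(F)(F)F)cc2-c2ccc(OC)c(C)c2)cc1CO`, has not yet been measured; it applies the same change to compound 2, namely (4-methoxy-3-methylphenyl in place of 4-bromophenyl on an aromatic carbon), at a place described in the same words. Within the data shown here, the step from compound 2 to compound 4 is expected to be a 1.4-fold lower number from compound 2 to compound 4 (0.16 log units; within the scatter), an expectation that rests on a 1.6-fold lower number from compound 1 to compound 3 (0.19 log units; within the scatter) as the only earlier example of this change. Compound 4 is accordingly estimated at 5 mg/kg, with a likely range from 2.5 mg/kg to 10 mg/kg.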

Compound 4, dose for half-maximal effect: 6.2 mg/kg
Compound 4: middle estimate off by 1.2-fold (0.09 log units), on the low side; measured number inside the range.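

In this assay, putting 4-methoxy-3-methylphenyl in place of 4-bromophenyl on the core of compound 2 gave a 1.2-fold lower number from compound 2 to compound 4 (0.06 log units; within the scatter). Set beside the same swap on the core of compound 1, the two steps agree: the same change on two cores in this assay, a 1.6-fold lower number (0.19 log units; within the scatter) from compound 1 to compound 3 and a 1.2-fold lower number (0.06 log units; within the scatter) from compound 2 to compound 4, 1.3-fold (0.13 log units) apart, within the scatter of two such steps. The swap therefore made no clear difference on either core, which shows that its small effect carried over between these two cores but sets no rule for other cores in the series.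

The compounds shown leave open whether a phenyl ring bearing an amine or a carboxylic acid would give a clear step at this place. They also leave open whether that step would carry across both cores.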